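The compounds below may be only part of what the source reports. "The series", "measured", "known", "first", "only" and "open" are said of these compounds alone.

Working notes on the series in an ADME assay on MRC5 cells (Homo sapiens) for cytotoxicity, read by MTT assay, with a stated time of 6 days; on this read-out higher numbers stand for weaker inhibition and lower numbers for stronger inhibition.

Three compounds of the series have been run so far, and none of them returned a number. Compound 1 `CC(=O)O[C@@H]1C=CC(=O)O[C@@H]1[C@@H](COC(=O)c1ccc(Cl)cc1)OC(C)=O` reached only the limit of the assay, giving > 100000 nM in this assay. Compound 2 `CC(=O)O[C@@H]1C=CC(=O)O[C@@H]1[C@@H](COC(=O)c1ccc([N+](=O)[O-])cc1)OC(C)=O` likewise stopped at the limit, giving > 100000 nM in this assay. Among the compounds with values here, the one readable pair among them, a step that the two limits leave unreadable from compound 1 to compound 2, is therefore unreadable in size. Compound 3 `O=C1C=C[C@@H](OCc2ccccc2)[C@@H]([C@@H](COC(=O)/C=C/c2ccccc2)OCc2ccccc2)O1`, the parent of the present step, also sits at the limit, giving > 100000 nM in this assay; its standing can be described only as a limit, not as a value, and the limit of > 100000 nM in this assay, at which 3 of the 3 values shown sit, is the whole of the evidence on the measured steps.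

Compound 4 `COc1ccc(/C=C/C(=O)OC[C@@H](OCc2ccccc2)[C@H]2OC(=O)C=C[C@H]2OCc2ccccc2)cc1` is obtained from compound 3 by methoxy in place of hydrogen on an aromatic carbon. Within the data shown here, no measured step in this assay bears on such a change, and no measured step in this assay has any readable size at all. The expectation for the step from compound 3 to compound 4 in this assay, a step that the limit leaves unreadable from compound 3 to compound 4, is accordingly none beyond the scatter, with a high chance that compound 4 again returns only a limit. Compound 4 is estimated at 150000 nM in this assay, within 50000 nM to 500000 nM.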

Compound 4, half-maximal inhibitory concentration: > 100000 nM
Compound 4 ended at the assay's limit (the forecaster's own chance of this, stated with the estimate: 85%); the middle value is on the limit's open side.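

No step can be read from compound 3 to compound 4, as both stand only at a limit of this assay, not at a number: the limit of > 100000 nM in this assay, at which 4 of the 4 values shown sit.

The compounds shown leave open whether any change to the series gives a readable value in this assay, and so what size any step, including methoxy in place of hydrogen, would have.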